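The compounds below may be only part of what the source reports. "The series", "measured", "known", "first", "only" and "open" are said of these compounds alone.

Compound 2 `CN(CCCN1CCCCC1)c1cccc(C(=O)N2CCc3ccc(OS(N)(=O)=O)cc3C2)c1` gives 24.1% in an assay on HEK293 cells for inhibition of Steryl-sulfatase (Homo sapiens), tested at 0.1 uM (a higher number here means a stronger effect of the compound at the concentration tested, a lower number a weaker effect), the second highest of three numbers: compound 3 `CN(C)CCCN(Cc1ccccc1)c1ccc(C(=O)N2CCc3ccc(OS(N)(=O)=O)cc3C2)cc1` gives 16.2%, within the scatter of it, while compound 1 `NS(=O)(=O)Oc1ccc2c(c1)CN(C(=O)c1ccc(N(Cc3ccccc3)Cc3ccco3)cc1)CC2` gives 90.8%, far higher. Compound 4 `NS(=O)(=O)Oc1ccc2c(c1)CN(C(=O)c1cccc(N3CCc4ccccc4C3)c1)CC2` differs from compound 2 by 1,2,3,4-tetrahydroisoquinolin-2-yl in place of methyl(3-(piperidin-1-yl)propyl)amino on an aromatic carbon. Among the measured compounds shown here, the only step measured within one change, a number 74.6 percentage points lower from compound 1 to compound 3 (beyond the scatter), bears on it: exchanging a furan-2-yl-bearing group on the aryl nitrogen for a 2-(dimethylamino)ethyl chain cost most of the inhibition. Compound 4 moves the other way, dropping the methyl(3-(piperidin-1-yl)propyl)amino group for a ring-bound nitrogen, so a step up beyond the scatter is expected, a number 37.9 percentage points higher from compound 2 to compound 4 (beyond the scatter), though the change is not a direct reversal and the size is uncertain. Compound 4 is estimated at 62%, between 32% and 88%.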

Compound 4, a percentage reported as inhibition, at one concentration (the size of the read-out at that concentration, not a potency): 24.1%
Compound 4: middle estimate off by 37.9 percentage points, on the high side; measured number below the stated range.
By their numbers in this assay, from the lowest: compounds 3, 2 and 4 (each within the scatter of the next); then compound 1.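

In this assay, 1,2,3,4-tetrahydroisoquinolin-2-yl in place of methyl(3-(piperidin-1-yl)propyl)amino on an aromatic carbon meta to a large group gives no change at the digits printed from compound 2 to compound 4 (within the scatter). At this place, then, the read-out does not separate the open chain ending in piperidine from the ring-bound nitrogen of the fused group. Nothing measured here explains this result.

Still open, on these data alone, is how this place responds to a much smaller group, such as methoxy or a primary amine. A chain ending in a carboxylic acid also remains untested in the compounds shown.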